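This account rests on a few compounds, and the source may have more. Where it says the series, first, only, none or still open, it means among the compounds named here.

Compound 1 `CN(C)CCN1CCN(CC(=O)Nc2ccc(-c3nc4cc(Cl)ccc4o3)cc2)CC1`: 1030 nM
Compound 2 `CN(C)CCN1CCN(CC(=O)Nc2ccc(-c3nc4ccccc4o3)cc2)CC1`: 7010 nM
Compound 3 `Cc1cc(-c2nc3cc(Cl)ccc3o2)ccc1NC(=O)CN1CCN(CCCN(C)C)CC1`: 14200 nM

The values above come from a functional assay on C6 cells (Rattus norvegicus) for cytotoxicity, read by MTT assay, with a stated time of 24 h; a lower number here means a stronger inhibitor, a higher number a weaker inhibitor. Compound 4 `Cc1cc(-c2nc3ccccc3o2)ccc1NC(=O)CN1CCN(CCCN(C)C)CC1` has not yet been measured in this assay.

Compound 1 and compound 2 differ in a single place: hydrogen in place of chloro on an aromatic carbon. That change moved the half-maximal inhibitory concentration by a 6.8-fold higher number from compound 1 to compound 2 (0.83 log units; beyond the scatter), a modest weakening. Compound 3 carries the same chloro-bearing core as compound 1, but the two differ elsewhere as well, and the difference between their cores is not broken down here. Among the three measured compounds, compound 3 gives the highest number, and its separation from both compound 1 and compound 2 lies beyond the usual scatter.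

Compound 4 is related to compound 3 exactly as compound 2 is related to compound 1: hydrogen in place of chloro on an aromatic carbon. The place of the change is described in identical words for both pairs, so this is the same change seen once more. For the measured compounds named here, compound 4 is therefore expected to give a higher number than compound 3, with a step of about a 4.2-fold higher number from compound 3 to compound 4 (0.63 log units; beyond the scatter), because the only measured example of this change, a 6.8-fold higher number from compound 1 to compound 2 (0.83 log units; beyond the scatter), ran in that direction. Compound 4 is expected to give roughly 60000 nM in this assay. Compound 4 would then be expected to fall between 20000 nM and 200000 nM, with a real chance that the assay reports only a limit.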

Compound 4, half-maximal inhibitory concentration: 38700 nM
For compound 4 the middle estimate is 1.6-fold (0.19 log units) above the measured one; low and high end bracket the measured number.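

In this assay, going from 5-chloro-1,3-benzoxazol-2-yl to 1,3-benzoxazol-2-yl again gave a weaker inhibitor, with a 2.7-fold higher number from compound 3 to compound 4 (0.44 log units; beyond the scatter) as the new step. Set beside the earlier step, it runs in the same direction, and the gap between the two lies within the usual scatter, so the two sizes cannot be told apart: the same change on two cores in this assay, a 6.8-fold higher number (0.83 log units; beyond the scatter) from compound 1 to compound 2 and a 2.7-fold higher number (0.44 log units; beyond the scatter) from compound 3 to compound 4, 2.5-fold (0.40 log units) apart, within the scatter of two such steps. This shows that, in these two pairs, the loss of the chloro group carried over from one core to the other with a consistent direction and a comparable size, but two pairs do not show that it would hold on any further core in the series, and they say nothing about why the chloro-bearing compounds give the lower numbers.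

The compounds shown leave open whether another group on the same aromatic carbon, such as fluoro, bromo or methoxy, would give a number closer to that of chloro or to that of hydrogen. They also leave open whether the step would keep its direction and size on a core with a longer chain or with a carboxylic acid in place of the terminal amine.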